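From methanesulfonamide to methylsulfamoyl on a shared core

A few compounds are considered here, and "the series" means these few. Any claim that something is new, unique, unknown or untested is made for them only; others in the source may bear on it.

In a functional assay on the whole organism for inhibition, with Mus musculus as the target (a higher number here means that more compound is needed for the effect, a lower number that less compound is needed), compound 2 `CCN1CCCC1CNC(=O)c1cc(NS(C)(=O)=O)c(C)cc1OC` gives 35.6 mg/kg, and compound 1 `CCN1CCCC1CNC(=O)c1cc(N(C)S(C)(=O)=O)c(C)cc1OC` gives 26.1 mg/kg; the two numbers lie within the usual scatter of each other. For the measured compounds named here, the one measured step, a 1.4-fold higher number from compound 1 to compound 2 (0.13 log units; within the scatter), altered only the sulfonamide nitrogen. Compound 3 `CCN1CCCC1CNC(=O)c1cc(NS(=O)(=O)NC)c(C)cc1OC` differs from compound 2 by methylamino in place of methyl on a sulfonyl sulfur. That earlier step touched a different atom and stayed within the scatter, so it bears only loosely here. For compound 3 the expected step is a 1.0-fold higher number from compound 2 to compound 3 (0.00 log units; within the scatter), nothing beyond the scatter. Compound 3 is estimated at 36 mg/kg, ranging from 15 mg/kg to 90 mg/kg.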

Compound 3, dose for half-maximal effect: > 50 mg/kg
Compound 3: no number, only a limit; the forecaster's own chance of this, stated with the estimate: 5%; middle value at least 1.3-fold (0.14 log units) from the limit.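

Compound 3 reaches only a limit of the assay: the limit of > 50 mg/kg in this assay, at which 1 of the 3 values shown sits. Methylamino in place of methyl on a sulfonyl sulfur gives an at least 1.4-fold higher number from compound 2 to compound 3 (0.14 log units; that floor lies within the scatter), and the comparison with the N-methyl sulfonamide gives an at least 1.9-fold higher number from compound 1 to compound 3 (0.28 log units; that floor lies within the scatter). Both floors lie within the scatter, so this first change at the sulfonyl sulfur shows no gain, but its true size could be small or large.

As far as these compounds go, how much more compound 3 needs remains open. So does how an ethyl or dimethylamino group on that sulfur would compare with methyl.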